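A few compounds are considered here, and "the series" means these few. Any claim that something is new, unique, unknown or untested is made for them only; others in the source may bear on it.

Within the data shown here, in an assay on isolated protein for inhibition of Bile acid receptor (Homo sapiens), read by TR-FRET and LanthaScreen (on this read-out lower numbers stand for stronger inhibition and higher numbers for weaker inhibition), compound 1 `Cn1c([C@H](CC2CCCCC2)N2C(=O)CN(c3ccc(Oc4ccccc4)cc3)C2=O)nc2ccc(C(=O)O)cc21` gives 24400 nM, the lowest of the three numbers measured so far. Compound 2 `Cc1ccc2nc([C@H](CC3CCCCC3)N3C(=O)CN(c4ccc(Oc5ccccc5)cc4)C3=O)n(C)c2c1` gives 126000 nM, and compound 3 `COc1ccc(Oc2ccc(N3CC(=O)N([C@@H](CC(C)C)c4nc5ccc(C(=O)O)cc5n4C)C3=O)cc2)cc1` gives 75300 nM. Among the measured compounds shown here, the only step between compounds differing in one place, a 5.2-fold higher number from compound 1 to compound 2 (0.71 log units; beyond the scatter), concerns another part of the molecule and does not bear on the present change. Compound 4 `CC(C)[C@@H](c1nc2ccc(C(=O)O)cc2n1C)N1C(=O)CN(c2ccc(Oc3ccccc3)cc2)C1=O` differs from compound 1 in one place: isopropyl in place of cyclohexylmethyl on a saturated chain carbon bound to an amide-type nitrogen in a ring and an aromatic carbon. Compound 3 carries a different group at that same place together with a further change elsewhere, so its gap to compound 1 offers only a loose hint that the number may move upward. Compound 4 is therefore expected to show a 2.0-fold higher number from compound 1 to compound 4 (0.31 log units; beyond the scatter), giving an estimated 50000 nM, with a range from 18000 nM to 150000 nM.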

Compound 4, half-maximal inhibitory concentration: 175000 nM
The estimate for compound 4 lay 3.5-fold (0.54 log units) below the measured number; measured number outside the range, above it.
By their numbers in this assay, from the lowest: compound 1; then compounds 3, 2 and 4 (each within the scatter of the next, the first and the last beyond it).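

Among these compounds, replacing cyclohexylmethyl with isopropyl on this saturated chain carbon gives a 7.2-fold higher number from compound 1 to compound 4 (0.86 log units; beyond the scatter) with the rest of the molecule unchanged, the first clean reading of this position. In this single pair, the group with the six-membered ring goes with stronger inhibition, so the position does respond to the choice of group. No available evidence explains this shift. From the compounds shown here alone, it remains open whether benzyl, a longer chain such as n-hexyl, or a chain carrying an amine would give a lower or a higher number than cyclohexylmethyl.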